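Compound 4: an open chain kept, a smaller amine end

The compounds below may be only part of what the source reports. "The series", "measured", "known", "first", "only" and "open" are said of these compounds alone.

Measured in a physicochemical assay for solubility, read by nephelometry, measured as kinetic solubility, with a stated time of 30 min; on this read-out lower numbers stand for lower solubility and higher numbers for higher solubility:
- compound 1 `c1cc([C@H]2CC[C@]3(CC2)OOC2(O3)C3CC4CC(C3)CC2C4)ccc1OCCOC1CCNCC1`: 50 ug/mL
- compound 2 `CC(C)(O)CNCCCOc1ccc([C@H]2CC[C@]3(CC2)OOC2(O3)C3CC4CC(C3)CC2C4)cc1`: > 100 ug/mL
- compound 3 `CC(C)(O)CN1CCC(Oc2ccc([C@H]3CC[C@]4(CC3)OOC3(O4)C4CC5CC(C4)CC3C5)cc2)CC1`: 1.6 ug/mL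

The reading for compound 2 of > 100 ug/mL is a limit and not a number, as the limit of > 100 ug/mL in this assay, at which 1 of the 3 values shown sits, records. Compound 2 therefore has no exact place on the scale.

Compound 4 `CC(C)(N)CCOc1ccc([C@H]2CC[C@]3(CC2)OOC2(O3)C3CC4CC(C3)CC2C4)cc1` differs from compound 2 as follows: 1-amino-1-methylethyl in place of ((2-hydroxy-2-methylpropyl)amino)methyl on a saturated chain carbon, two bonds along the chain from an oxygen on an aromatic ring. The nearest measured step, at that same place on the chain, is an at least 2.0-fold higher number from compound 1 to compound 2 (0.30 log units; that floor lies within the scatter). The two large steps, a 31-fold lower number from compound 1 to compound 3 (1.49 log units; beyond the scatter) and an at least 62-fold lower number from compound 2 to compound 3 (1.79 log units; beyond the scatter), both install 1-(2-hydroxy-2-methylpropyl)piperidin-4-yl on the oxygen on the aromatic ring. Compound 4 lacks that group, so no fall of that size is expected. A modest downward move in this assay is expected, and it may not clear the scatter. The expected step is an at least 1.8-fold lower number from compound 2 to compound 4 (0.25 log units; that floor lies within the scatter). For compound 4 the estimated value is 55 ug/mL, with an expected range of 15 ug/mL to 100 ug/mL.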

Compound 4, solubility: 50 ug/mL
Compound 4: the middle estimate sits 1.1-fold (0.04 log units) above what was measured, and the stated range covers the measured number.
By their numbers in this assay, from the lowest: compound 3; then compounds 1 and 4 (each within the scatter of the next). At a limit, above all of these: compound 2.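

At this place on the chain, a much smaller amine end still keeps the reading well clear of compound 3 in this assay: 3-amino-3-methylbutyl in place of 1-(2-hydroxy-2-methylpropyl)piperidin-4-yl on the oxygen on the aromatic ring gives a 31-fold higher number from compound 3 to compound 4 (1.49 log units; beyond the scatter). The exchange of (piperidin-4-yl)oxy for 1-amino-1-methylethyl gives no change at the digits printed from compound 1 to compound 4 (within the scatter), so two quite different chain ends read alike. Losing the 2-hydroxy-2-methylpropyl part of the chain end gives an at least 2.0-fold lower number from compound 2 to compound 4 (0.30 log units; that floor lies within the scatter), a step that starts from a limit and not a number: the limit of > 100 ug/mL in this assay, at which 1 of the 4 values shown sits.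

Going by these compounds, whether a chain ending in a hydroxyl group with no amine, or in a carboxylic acid, would hold this reading stays open. So does the true distance between compound 2 and compound 4, which a limit cannot tell.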